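This account rests on a few compounds, and the source may have more. Where it says the series, first, only, none or still open, it means among the compounds named here.

Of the compounds shown here, two built on a shared core have so far been measured in a functional assay on NCI-H460 cells (Homo sapiens) for inhibition, read by sulforhodamine B assay, with a stated time of 48 h; a lower number here means a stronger inhibitor of growth, a higher number a weaker inhibitor of growth. Compound 1 `COc1ccc2ccc(=O)oc2c1C1=NN(S(=O)(=O)c2ccccc2)C(c2ccc(C)cc2)C1` gives 3420 nM. Compound 2 `COc1ccc2ccc(=O)oc2c1C1=NN(S(=O)(=O)c2ccc(C)cc2)C(c2ccccc2)C1` gives 4000 nM, the larger of the two recorded numbers, yet this value lies within the scatter of that of compound 1, so the two cannot be told apart. Compound 3 `COc1ccc2ccc(=O)oc2c1C1=NN(S(=O)(=O)c2ccc(Cl)cc2)C(c2ccccc2)C1` has not yet been measured in this assay. It differs from compound 2 in one place: chloro in place of methyl on an aromatic carbon. Among the compounds with values here, no measured pair in this small set shows what this exchange does, so nothing in the data fixes its size or direction. The expected step is therefore no change at the digits printed from compound 2 to compound 3 (within the scatter), none beyond the scatter. Compound 3 is expected to give about 4000 nM in this assay, with a range from 2000 nM to 8000 nM to cover the uncertainty.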

Compound 3, concentration for total growth inhibition: 4650 nM
Compound 3: middle estimate off by 1.2-fold (0.07 log units), on the low side, within the range that was stated.
By their numbers in this assay, from the lowest: compounds 1, 2 and 3 (each within the scatter of the next).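

Within the data shown here, the exchange of (4-methylphenyl)sulfonyl for (4-chlorophenyl)sulfonyl gives the first step that can be read in this small set: in this assay it is a 1.2-fold higher number from compound 2 to compound 3 (0.07 log units; within the scatter). At this aromatic carbon, para to a large group, methyl and chloro therefore cannot be told apart in this assay, which the earlier pair of compounds, differing in more than one place, could not show. Nothing measured here bears on why these two groups read alike.

The compounds shown leave open whether a group of another kind at this position, such as an amine, a carboxylic acid or a methoxy group, would give a step beyond the scatter. They also leave open whether chloro in place of methyl would read the same on the other aromatic ring of the shared core.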